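The compounds below may be only part of what the source reports. "The series", "measured", "known", "first", "only" and "open" are said of these compounds alone.

Going by the values given here, compound 2 `COc1ccc(-c2nn(-c3ccccc3)c3ncc(CCCO)cc23)cc1` stands at the lower of the two numbers measured so far in a functional assay on THP-1 cells (Homo sapiens) for cytotoxicity, tested at 10 uM; on this read-out lower numbers stand for less inhibition and higher numbers for more inhibition at the one concentration tested (going by the name of the read-out): compound 2 gives 10%. Its nearest neighbour, compound 1 `Cc1nn(-c2ccccc2)c2ncc(CCCO)cc12`, gives 16% in this assay. Among the compounds with values here, the only measured step, a number 6 percentage points lower from compound 1 to compound 2 (within the scatter), is within the scatter and concerns another part of the shared core: 4-methoxyphenyl in place of methyl on an aromatic carbon.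

Compound 3 `COc1ccc(-c2nn(-c3ccccc3)c3ncc(C(=O)c4cc(C)ccc4O)cc23)cc1` differs from compound 2 by (2-hydroxy-5-methylphenyl)carbonyl in place of 3-hydroxypropyl on an aromatic carbon. Within the data shown here, no measured step bears on this part of the core or on this kind of exchange; the one step known, from compound 1 to compound 2, changes another group and is within the scatter. Among the measured compounds shown here, both measured numbers are low on this read-out, and there is no precedent for the entering group. The estimate therefore rests on compound 2, with 10%, and allows a wider range. Compound 3 is expected to give 15% in this assay, with a range from 0% to 35%, which means an expected step of a number 5 percentage points higher from compound 2 to compound 3 (within the scatter), within the scatter.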

Compound 3, a percentage reported as inhibition, at one concentration (the size of the read-out at that concentration, not a potency): 27%
For compound 3 the middle estimate is 12 percentage points below the measured one; the range from low to high includes it.
By their numbers in this assay, from the lowest: compounds 2 and 1 (each within the scatter of the next); then compound 3.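

Going by these compounds alone, at the position two atoms from the ring nitrogen, (2-hydroxy-5-methylphenyl)carbonyl in place of 3-hydroxypropyl gives, in this assay, a number 17 percentage points higher from compound 2 to compound 3 (beyond the scatter), the first step to lie beyond the scatter, so this position can move the read-out at the one concentration tested. The exchange replaces a chain without a ring by a larger group of 10 heavy atoms that brings in a carbon-only aromatic ring and a carbonyl, so these features change together and the step belongs to the group as a whole, not to any one part of it. No measurement shown here accounts for the size or direction of the step.

On these data alone, it remains open which part of the entering group carries the step, a question that a plain phenylcarbonyl group, without the hydroxyl and methyl substituents, would help to settle. Also open, as far as these compounds go, is whether a non-aromatic replacement at this position, such as a longer chain ending in an amine or a carboxylic acid, would move the read-out in the same direction.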